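Removing a methyl from a side chain on two related cores

The source may hold more compounds than are shown below. What is called first, only, known or untested is meant among the compounds shown, and "the series" means these compounds.

Compound 3 `COCCNC(=C\C(=O)/C=C/c1ccc(O)c(OC)c1)/C=C/c1ccc(O)c(OC)c1` and compound 1 `COc1cc(/C=C/C(=O)/C=C(/C=C/c2ccc(O)c(OC)c2)NCCO)ccc1O` share one core and differ only in one place: hydrogen in place of methyl on an oxygen on a saturated carbon. In a functional assay, read by spectrophotometry, with a stated time of 30 min (a lower number here means that less compound is needed, a higher number that more compound is needed for the effect), compound 3 gives 27300 nM, and compound 1 gives 28300 nM. The step of a 1.0-fold higher number from compound 3 to compound 1 (0.02 log units; within the scatter) shows that this change left the reading essentially unaltered.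

Compound 2 `COCCNC(=C\C(=O)/C=C/c1ccc(O)cc1)/C=C/c1ccc(O)cc1` sits on a second core; how this core differs from the core of compound 3 is not broken down here. In this assay compound 2 gives > 200000 nM, which is a limit of the measurement and not a number.

Compound 4 `O=C(/C=C(/C=C/c1ccc(O)cc1)NCCO)/C=C/c1ccc(O)cc1` is obtained from compound 2 by the same change: hydrogen in place of methyl on an oxygen on a saturated carbon. Going by the values given here, since compound 2 is known only through (the limit of > 200000 nM in this assay, at which 1 of the 3 values shown sits), and the one measured instance of this change, a 1.0-fold higher number from compound 3 to compound 1 (0.02 log units; within the scatter), stayed within the scatter, the step that the limit leaves unreadable from compound 2 to compound 4 is expected to be small as well. Compound 4 is therefore estimated at 250000 nM in this assay, most likely again reported only as a limit.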

Compound 4, half-maximal effective concentration in the functional assay: > 200000 nM
Compound 4: only a limit was reported; the forecaster's own chance of this, stated with the estimate: 80%; the middle value does not contradict the limit.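

In the functional assay compound 2 gives > 200000 nM, which is a limit of the assay and not a number. In the functional assay compound 4 gives > 200000 nM, which is also a limit of the assay and not a number. No step between these two compounds can be read in the functional assay: the limit of > 200000 nM in the functional assay, at which 2 of the 4 values shown sit.

In a physicochemical assay for solubility, using the shake flask method, in phosphate buffer, with a stated time of 24 h, at pH 6.8 (a higher number here means a more soluble compound, a lower number a less soluble compound), compound 2 gives 46100 nM, and compound 4 gives 37900 nM. In the physicochemical assay the step is a 1.2-fold lower number from compound 2 to compound 4 (0.09 log units; within the scatter).

The compounds shown leave open how far 2-hydroxyethyl in place of 2-methoxyethyl shifts the reading on the core of compound 2 in the functional assay, where neither compound has a number.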